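The source may hold more compounds than are shown below. What is called first, only, known or untested is meant among the compounds shown, and "the series" means these compounds.

In a functional assay on the whole organism (Tail, strain ICR) with Mus musculus as the target, in the tail flick test, with a stated time of 30 min, at a dose of 25 umol/kg by the oral route (a higher number here means a stronger effect of the compound at the dose given, a lower number a weaker effect), compound 3 `NC(=O)C[C@H](NC(=O)CN(c1ncnc2c1ncn2C1CCCCO1)C1CC1)C(=O)OCc1ccccc1` gives 34.5%, the second highest of the three numbers measured. Compound 2 `O=C(CN(c1ncnc2c1ncn2C1CCCCO1)C1CC1)N[C@@H](CO)C(=O)OCc1ccccc1` gives 27.8%, and compound 1 `N=C(N)NCCC[C@H](NC(=O)CN(c1nc(Cl)nc2[nH]cnc12)C1CC1)C(=O)O` gives 45.4%, so compound 3 sits nearer to compound 2 than to compound 1. Compound 4 `CC(C)[C@H](NC(=O)CN(c1ncnc2c1ncn2C1CCCCO1)C1CC1)C(=O)OCc1ccccc1` differs from compound 3 in one place: isopropyl in place of carbamoylmethyl on a saturated chain carbon bound to an amide-type nitrogen and a carbonyl carbon. Among the compounds with values here, the only measured single-place step is a number 6.7 percentage points higher from compound 2 to compound 3 (within the scatter), an exchange of a hydroxy for a carbamoyl on the same chain carbon; it does not involve the isopropyl and stayed within the scatter, so no measured step bears directly on this change. With that little to go on, compound 4 is expected to move by about a number 3.5 percentage points lower from compound 3 to compound 4 (within the scatter), that is no change beyond the scatter. Compound 4 is estimated at 31%, between 16% and 46%.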

Compound 4, a percentage reported as activity, at one dose (the size of the read-out at that dose, not a potency): 21.8%
For compound 4 the middle estimate is 9.2 percentage points above the measured one; measured number inside the range.
By their numbers in this assay, from the lowest: compounds 4, 2 and 3 (each within the scatter of the next, the first and the last beyond it); then compound 1.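

Within the data shown here, at the saturated chain carbon bound to an amide-type nitrogen and a carbonyl carbon, isopropyl in place of carbamoylmethyl gives, in this assay, a number 12.7 percentage points lower from compound 3 to compound 4 (beyond the scatter), the first single-place step here to pass the scatter, so the group at this position can matter. Isopropyl in place of hydroxymethyl at the same carbon gives a number 6 percentage points lower from compound 2 to compound 4 (within the scatter), so this exchange cannot be told from scatter. Nothing available explains the larger step. As far as these compounds go, it remains open how an amine, a carboxylic acid or a longer chain at this carbon would read.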